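Oxan-4-yl to 1-methylpiperidin-4-yl on the shared core

A few compounds are considered here, and "the series" means these few. Any claim that something is new, unique, unknown or untested is made for them only; others in the source may bear on it.

In a physicochemical assay for lipophilicity, read by HPLC, using the shake flask method, measured as octanol-water partition, at pH 7.4 (on this read-out higher numbers stand for higher lipophilicity and lower numbers for lower lipophilicity), compound 1 (`Cc1cc2nnccc2cc1Nc1ncc2c(n1)n(C1CCOCC1)c(=O)n2C`) reads 2.2 and stands level, within the scatter, with compound 2 (`Cc1cc2ncncc2cc1Nc1ncc2c(n1)n(C1CCOCC1)c(=O)n2C`) at 2.2 on the same measure. Among the measured compounds shown here, these two values are all that is in hand, and no measured pair differs in one place, so nothing here calibrates the next change.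

Compound 3 (`Cc1cc2nnccc2cc1Nc1ncc2c(n1)n(C1CCN(C)CC1)c(=O)n2C`) is still unmeasured. It departs from compound 1 in one place: 1-methylpiperidin-4-yl in place of oxan-4-yl on an aromatic nitrogen with 1-methylpiperidin-4-yl in place of oxan-4-yl on an aromatic nitrogen. Both groups are a six-membered non-aromatic ring with 1 hetero atom, oxygen leaving and nitrogen entering, and the rest of the core of compound 1 stays as it is.

For the measured compounds named here, with no measured step to lean on, the expectation is a judgement and the range is kept wide. The estimated step is a number 0.40 log units lower from compound 1 to compound 3 (beyond the scatter) in this assay and would be a modest fall, a little beyond the scatter. For compound 3 the estimated value is 1.8 with an expected range from 1.2 to 2.4 in this measurement.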

Compound 3, distribution coefficient: 1.2
The estimate for compound 3 lay 0.60 log units above the measured number; the range from low to high includes it.
By their numbers in this assay, from the lowest: compound 3; then compounds 1 and 2 (each within the scatter of the next).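

In this assay, the position on the aromatic nitrogen now has its first measured step, and the read-out responds to this exchange: 1-methylpiperidin-4-yl in place of oxan-4-yl gives a number 1.00 log units lower from compound 1 to compound 3 (beyond the scatter) on the shared core. Compounds 1 and 2 could not show this, since they share the oxan-4-yl group and differ elsewhere. The step also arises between two groups that match in the computed counts of rings, hetero atoms, hydrogen-bond donors, hydrogen-bond acceptors and net charge, differing in ring nitrogen with its methyl group against ring oxygen, and no measurement on hand bears on why the read-out moves.

This single step does not show whether the same exchange on the core of compound 2 would give a step of similar size. It also leaves open how the read-out would respond to other groups at this position, such as piperidin-4-yl without the methyl group, 1-acetylpiperidin-4-yl or plain cyclohexyl, which would help separate the contribution of the ring nitrogen from that of its methyl group.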